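Moving the primary amine onto a cyclohexyl ring

The compounds below may be only part of what the source reports. "The series", "measured", "known", "first", "only" and "open" are said of these compounds alone.

Two compounds carry the same decyl-bearing core and differ only in the group on the five-membered aromatic ring. Compound 1 `CCCCCCCCCCc1ccc(-c2noc(CCCCN)n2)cc1` gives 55% in an assay on HeLa cells for inhibition of sphingosine-1-phosphate transporter SPNS2 (Mus musculus), read by LC-MS, tested at 2 uM (on this read-out higher numbers stand for more inhibition at the one concentration tested (going by the name of the read-out) and lower numbers for less inhibition), and compound 2 `CCCCCCCCCCc1ccc(-c2noc(CN3CCNCC3)n2)cc1` gives 19% in this assay. Among the measured compounds shown here, the only step so far, a number 36 percentage points lower from compound 1 to compound 2 (beyond the scatter), is the one relevant here; it shows that exchanging the 3-aminopropyl for a piperazin-1-yl ring costs a great deal of inhibition. Among the two measured compounds, compound 2 stands lowest, with compound 1 the nearest and well above it beyond the scatter.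

Compound 3 `CCCCCCCCCCc1ccc(-c2noc([C@H]3CCC[C@@H](N)C3)n2)cc1` has not been measured. Relative to compound 2 it changes as follows: 3-aminocyclohexyl in place of (piperazin-1-yl)methyl on an aromatic carbon. The change restores a primary amine, the feature that compound 1 holds, and removes the ring that bears two nitrogens. For the measured compounds named here, on the strength of the step from compound 1 to compound 2 being a number 36 percentage points lower from compound 1 to compound 2 (beyond the scatter), the account expects the reverse direction for compound 3, a step of about a number 31 percentage points higher from compound 2 to compound 3 (beyond the scatter) in this assay, though the carbocycle with its two defined stereocentres has no measured precedent, so the range is wide. Compound 3 is therefore estimated at 50% in this assay, within 25% to 75%.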

Compound 3, a percentage reported as inhibition, at one concentration (the size of the read-out at that concentration, not a potency): 29%
For compound 3 the middle estimate is 21 percentage points above the measured one, within the range that was stated.
By their numbers in this assay, from the lowest: compounds 2 and 3 (each within the scatter of the next); then compound 1.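

In this assay, a primary amine in the group at this position is not enough on its own to match compound 1: the change gives a number 10 percentage points higher from compound 2 to compound 3 (within the scatter) and so does not separate 3-aminocyclohexyl from (piperazin-1-yl)methyl, although one ring is carbon only and the other holds two hetero atoms. Exchanging the 4-aminobutyl of compound 1 for 3-aminocyclohexyl gives a number 26 percentage points lower from compound 1 to compound 3 (beyond the scatter) even though both groups carry a primary amine, so among these three compounds the open-chain 4-aminobutyl stands alone above the two groups with a six-membered ring, and compound 3 goes against any simple link between the primary amine and a higher number. Nothing measured here accounts for this difference.

The compounds shown leave open whether the other stereoisomers of 3-aminocyclohexyl would behave like compound 3, and whether a 4-aminocyclohexyl group would do so too. They also leave open how a shorter or longer aminoalkyl chain, such as 2-aminoethyl or 5-aminopentyl, would compare with the 4-aminobutyl of compound 1.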